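Replacing a ring side group with dimethylcarbamoyl

The source may hold more compounds than are shown below. What is called first, only, known or untested is meant among the compounds shown, and "the series" means these compounds.

In a functional assay on SW480 cells (Homo sapiens) for antiproliferative activity, read by MTT assay, with a stated time of 48 h (a lower number here means a stronger inhibitor, a higher number a weaker inhibitor), compound 1 `CC(=O)OC/C1=C/C[C@](C)(CCC=C(C)C)/C=C/[C@@H](OC(=O)C=C(C)C)[C@](C)(O)/C=C/C1=O` gives 2950 nM, compound 2 `CSC(=S)OC/C1=C/C[C@](C)(CCC=C(C)C)/C=C/[C@@H](OC(=O)C=C(C)C)[C@](C)(O)/C=C/C1=O` gives 390 nM and compound 3 `CO/N=C/C1=C/C[C@](C)(CCC=C(C)C)/C=C/[C@@H](OC(=O)C=C(C)C)[C@](C)(O)/C=C/C1=O` gives 2630 nM. Compound 3 therefore sits level with compound 1, as shown by a 1.1-fold lower number from compound 1 to compound 3 (0.05 log units; within the scatter), and apart from compound 2, as shown by a 6.7-fold higher number from compound 2 to compound 3 (0.83 log units; beyond the scatter). Compound 4 `CC(C)=CCC[C@]1(C)/C=C/[C@@H](OC(=O)C=C(C)C)[C@](C)(O)/C=C/C(=O)/C(C(=O)N(C)C)=C\C1` carries dimethylcarbamoyl on the double-bonded ring carbon: a group of 5 heavy atoms (3 carbon, 1 nitrogen, 1 oxygen; no ring) in place of a group of 4 heavy atoms (2 carbon, 1 nitrogen, 1 oxygen; no ring), on a double-bonded ring carbon. Among the compounds with values here, the nearest precedent is compound 3, whose change at this carbon gave only a 1.1-fold lower number from compound 1 to compound 3 (0.05 log units; within the scatter). The larger 7.6-fold lower number from compound 1 to compound 2 (0.88 log units; beyond the scatter) came with the sulfur-bearing group of compound 2, and compound 4 has no sulfur. The expected step in this assay is therefore a 1.1-fold higher number from compound 3 to compound 4 (0.06 log units; within the scatter), none beyond the scatter. For compound 4, the estimate is 3000 nM, with an expected range of 1000 nM to 9000 nM.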

Compound 4, half-maximal inhibitory concentration: 3300 nM
For compound 4 the middle estimate is 1.1-fold (0.04 log units) below the measured one; measured number inside the range.
By their numbers in this assay, from the lowest: compound 2; then compounds 3, 1 and 4 (each within the scatter of the next).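

In this assay dimethylcarbamoyl on the double-bonded ring carbon stays level with the group of compound 3 (a 1.3-fold higher number from compound 3 to compound 4 (0.10 log units; within the scatter)) and with the acetoxymethyl of compound 1 (a 1.1-fold higher number from compound 1 to compound 4 (0.05 log units; within the scatter)). Like those two groups, it has no sulfur, and it does not match compound 2 (an 8.5-fold higher number from compound 2 to compound 4 (0.93 log units; beyond the scatter)). Nothing measured here explains these results. Still open, from the compounds shown here alone, is whether another sulfur-bearing group, such as a thiol, would match compound 2. An amine or a carboxylic acid on this carbon also remains untested in the compounds shown.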